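Dropping the methoxy group of compound 1

The source may report more compounds than this note shows. Statements on the series, on what has been measured and on what is new or still open speak of the compounds shown alone.

Compound 1 `COc1ccc2occ(CSC(=S)N(C(C)C)C(C)C)c(=O)c2c1` — 1800 nM
Compound 2 `O=c1cc(CSC(=S)N2CCN(c3ccccc3)CC2)oc2cc(Cl)ccc12` — 18600 nM
Compound 3 `COc1ccc2occ(CSC(=S)N3CCOCC3)c(=O)c2c1` — a limit, > 40000 nM

In a functional assay on MDA-MB-435S cells (Homo sapiens) for antiproliferative activity, read by MTT assay, with a stated time of 72 h (on this read-out lower numbers stand for stronger inhibition and higher numbers for weaker inhibition), compound 1 gives 1800 nM, the lowest of the two numbers shown. Compound 2, which carries a different amine and a chloro substituent, gives 18600 nM, a higher number. For compound 3 the read-out is a limit of the assay, > 40000 nM. For the measured compounds named here, the one step between compounds that differ in a single place is an at least 22-fold higher number from compound 1 to compound 3 (1.34 log units; beyond the scatter), where morpholin-4-yl replaces diisopropylamino on the thiocarbonyl carbon; this rests on (the limit of > 40000 nM in this assay, at which 1 of the 3 values shown sits), so its true size is not known.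

Compound 4 `CC(C)N(C(=S)SCc1coc2ccccc2c1=O)C(C)C` differs from compound 1 by hydrogen in place of methoxy on an aromatic carbon. Going by the values given here, no measured step touches this part of the shared core: the only measured step alters the amine, and compound 2 changes two places at once. There is thus no direct guide, and the expectation is a step from compound 1 to compound 4 of no size beyond the scatter, a 1.4-fold higher number from compound 1 to compound 4 (0.14 log units; within the scatter), with a wide band of uncertainty. Compound 4 is therefore estimated at 2500 nM in this assay, within a range from 700 nM to 9000 nM.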

Compound 4, half-maximal inhibitory concentration: 7900 nM
Compound 4: the middle estimate sits 3.2-fold (0.50 log units) below what was measured; measured number inside the range.
By their numbers in this assay, from the lowest: compound 1; then compound 4; then compound 2. At a limit, above all of these: compound 3.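

Replacing methoxy with hydrogen on the aromatic carbon, meta to a fused ring and para to a fused ring, while the diisopropylamino group stays in place, gives a 4.4-fold higher number from compound 1 to compound 4 (0.64 log units; beyond the scatter) in this assay. For the compounds shown here, the earlier compounds offered a clean single change only on the amine side, so this is the first sign that the read-out also responds to a change on the shared core, and that the methoxy group cannot be removed without a loss beyond the scatter. The compounds shown hold no measurement that accounts for this step.

As far as these compounds go, it stays open whether a hydroxy group, an ethoxy group or a fluorine on that same aromatic carbon would give a number closer to that of compound 1 or to that of compound 4. It also stays open whether the methoxy step carries over to other amines, and compound 3, the only other compound that shares the methoxy core, offers no such test, since its value is a limit: the limit of > 40000 nM in this assay, at which 1 of the 4 values shown sits.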